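Propargyl Cut Back to Methyl on the Amide Nitrogen

The source may hold more compounds than are shown below. What is called first, only, known or untested is meant among the compounds shown, and "the series" means these compounds.

Compound 1 `C#CCN(CC=C)C(=O)[C@@]1(c2ccsc2)C[C@H]1CN`: a limit, > 10000 nM in an assay on HEK293 cells for inhibition of sodium-dependent dopamine transporter (Homo sapiens); a higher number here means a weaker inhibitor, a lower number a stronger inhibitor
Compound 2 `CCN(CC)C(=O)[C@@]1(c2cc3cc(F)ccc3s2)C[C@H]1CN`: a limit, > 10000 nM in this assay
Compound 3 `C#CCN(CCOC)C(=O)[C@@]1(c2ccsc2)C[C@H]1CN`: a limit, > 10000 nM in this assay

Where compound 1 stands cannot be placed as a number: its value in this assay is a limit of the assay. The same holds for compound 2, whose value is a limit. Compound 3 also gives a limit. For the measured compounds named here, all three measured values sit at the limit of > 10000 nM in this assay, at which 3 of the 3 values shown sit, so no compound can be ranked against another.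

Compound 4 `C=CCN(C)C(=O)[C@@]1(c2ccsc2)C[C@H]1CN` differs from compound 1 in one place: hydrogen in place of ethynyl on a saturated chain carbon bound to an amide-type nitrogen. Going by the values given here, the only step measured in one place is a step that the two limits leave unreadable from compound 1 to compound 3, and it is unreadable, since both ends are limits. Among the compounds with values here, no measured step bears on the loss of an ethynyl group, and none shows any change that rises above the scatter.

With every value at the limit and no readable step, the expectation for compound 4 is that it stays at the limit in this assay, a step that the limit leaves unreadable from compound 1 to compound 4 that is expected to be unreadable as well. Compound 4 is therefore estimated at 25000 nM, within 6000 nM to 100000 nM.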

Compound 4, half-maximal inhibitory concentration: > 10000 nM
Compound 4: no number, only a limit (the forecaster's own chance of this, stated with the estimate: 85%); the middle value is on the limit's open side.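

In this assay compound 4 gives > 10000 nM, which is a limit of the assay. No step from compound 1 to compound 4 can be read, since both ends are limits: the limit of > 10000 nM in this assay, at which 4 of the 4 values shown sit.

The compounds shown leave open which change to the groups on the amide nitrogen or elsewhere, if any, would give a measurable value in this assay.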